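Replacing 2,4-dichlorophenyl on the amide-type nitrogen

The source may report more compounds than this note shows. Statements on the series, on what has been measured and on what is new or still open speak of the compounds shown alone.

In an ADME assay on MT4 cells (Homo sapiens) for cytotoxicity, read by MTT assay (on this read-out higher numbers stand for lower toxicity in this test and lower numbers for higher toxicity in this test), compound 1 (`Cc1cnc(NC(=O)CSc2nncnc2-c2ccccc2Cl)c(Br)c1`) gives 144000 nM and compound 2 (`Cc1ccccc1NC(=O)CSc1nncnc1-c1ccccc1Cl`) gives 142000 nM while compound 3 (`O=C(CSc1nncnc1-c1ccccc1Cl)Nc1ccc(Cl)cc1Cl`) gives 51000 nM as the lowest of the three numbers. Compound 4 (`COC(=O)c1sccc1NC(=O)CSc1nncnc1-c1ccccc1Cl`) has not yet been measured. It carries 2-(methoxycarbonyl)thiophen-3-yl in place of 2,4-dichlorophenyl on an amide-type nitrogen. Two measured steps at this place are modest but beyond the scatter (a 2.8-fold lower number from compound 1 to compound 3 (0.45 log units; beyond the scatter) and a 2.8-fold lower number from compound 2 to compound 3 (0.44 log units; beyond the scatter)) while a third stays within it (a 1.0-fold lower number from compound 1 to compound 2 (0.01 log units; within the scatter)). Compound 3 therefore sits apart from the other two, and leaving 2,4-dichlorophenyl is expected to raise the number by a similar modest size, the reverse of a 2.8-fold lower number from compound 2 to compound 3 (0.44 log units; beyond the scatter) in direction. Among the measured compounds shown here, no measured compound carries the entering group, so the expectation remains loose. The expected step is modest (a 2.2-fold higher number from compound 3 to compound 4 (0.33 log units; beyond the scatter)). In this assay compound 4 is estimated at 110000 nM (expected range 45000 nM to 220000 nM).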

Compound 4, half-maximal cytotoxic concentration: 105000 nM
Beside the measured number, compound 4's estimate is 1.0-fold (0.02 log units) above it; the range from low to high includes it.
By their numbers in this assay, from the lowest: compound 3; then compounds 4, 2 and 1 (each within the scatter of the next).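

In this assay the step of a 2.1-fold higher number from compound 3 to compound 4 (0.31 log units; beyond the scatter) shows that a second kind of group on the amide-type nitrogen, here a five-membered aromatic ring with 1 hetero atom, also leaves the low number of compound 3 behind. The other two steps, a 1.4-fold lower number from compound 2 to compound 4 (0.13 log units; within the scatter) and a 1.4-fold lower number from compound 1 to compound 4 (0.14 log units; within the scatter), place the new compound with the earlier pair, so among the four groups shown only 2,4-dichlorophenyl stands apart. Nothing shown here accounts for that separation.

The compounds shown leave open whether a phenyl ring carrying a single chlorine would stay with compound 3 or join the other three. They also leave open whether a carboxylic acid or an amine in place of the methoxycarbonyl would keep compound 4 with that group.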